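The source may report more compounds than this note shows. Statements on the series, on what has been measured and on what is new or still open speak of the compounds shown alone.

Compound 1 `COc1ccc(C(=O)c2cc(OC)c(OC)c(OC)c2)cc1NC(=O)/C=C/c1cc(OC)c(OC)c(OC)c1`: 2100 nM
Compound 2 `COc1ccc(/C=C/C(=O)Nc2cc(C(=O)c3cc(OC)c(OC)c(OC)c3)ccc2OC)cc1`: 11800 nM
Compound 3 `C#CCOc1cccc(/C=C/C(=O)Nc2cc(C(=O)c3cc(OC)c(OC)c(OC)c3)ccc2OC)c1`: 15300 nM

These three compounds were tested in a functional assay on ME-180 cells (Homo sapiens) for cytotoxicity, read by MTT assay, with a stated time of 72 h; a higher number here means a weaker inhibitor, a lower number a stronger inhibitor. Compound 1 gives the lowest number of the three, and both other compounds lie beyond the scatter from it: there is a 5.6-fold higher number from compound 1 to compound 2 (0.75 log units; beyond the scatter) and a 7.3-fold higher number from compound 1 to compound 3 (0.86 log units; beyond the scatter). Between compound 2 and compound 3 the gap is only a 1.3-fold higher number from compound 2 to compound 3 (0.11 log units; within the scatter), so those two cannot be ordered.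

Compound 4 `COc1ccc(C(=O)c2cc(OC)c(OC)c(OC)c2)cc1NC(=O)/C=C/c1cccc(OC(F)(F)F)c1` has not yet been measured in this assay. It differs from compound 1 in one place: 3-(trifluoromethoxy)phenyl in place of 3,4,5-trimethoxyphenyl on a double-bonded chain carbon bound to a double-bonded chain carbon. The two measured steps that bear on this change both replace the 3,4,5-trimethoxyphenyl with a phenyl carrying a single group, and both gave a modest rise in the number beyond the scatter. Compound 4 carries the 3-(trifluoromethoxy)phenyl, again a phenyl with a single group, so a step of similar size and direction is expected for compound 4, namely a 5.7-fold higher number from compound 1 to compound 4 (0.76 log units; beyond the scatter). For compound 4 the estimate in this assay is 12000 nM, with a range from 4000 nM to 40000 nM.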

Compound 4, half-maximal inhibitory concentration: 9200 nM
Beside the measured number, compound 4's estimate is 1.3-fold (0.12 log units) above it; measured number inside the range.
By their numbers in this assay, from the lowest: compound 1; then compounds 4, 2 and 3 (each within the scatter of the next).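

In this assay, the 3-(trifluoromethoxy)phenyl on a double-bonded chain carbon also gives up ground against the 3,4,5-trimethoxyphenyl (a 4.4-fold higher number from compound 1 to compound 4 (0.64 log units; beyond the scatter)), so compounds 2, 3 and 4 all show the rise at this place and no compound shown goes against it. Three quite different single-group phenyls now sit together, since compound 4 cannot be separated from either of the other two (a 1.7-fold lower number from compound 3 to compound 4 (0.22 log units; within the scatter); a 1.3-fold lower number from compound 2 to compound 4 (0.11 log units; within the scatter)), and a group carrying fluorine makes no readable difference here. Nothing measured here explains the rise.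

On these data alone, whether a phenyl carrying two methoxy groups would stand with compound 1 or with the other three remains open, as does the effect of an amine or a carboxylic acid on this ring. The compounds shown also do not tell whether any group at this place gives a lower number than compound 1 does.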